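The compounds below may be only part of what the source reports. "The series", "measured", "known", "first", "only" and "open" are said of these compounds alone.

Compound 1 `ClCc1ccccc1Cn1cnc2c(Cl)ncnc21` and compound 2 `ClCc1cccc(Cn2cnc3c(Cl)ncnc32)c1` are built from the same atoms joined differently; the difference between the two cores is not broken down here. In a functional assay on Hs-578T cells (Homo sapiens) for cytotoxicity, read by sulforhodamine B assay, with a stated time of 48 h (on this read-out higher numbers stand for lower toxicity in this test and lower numbers for higher toxicity in this test), compound 1 gives 56200 nM, and in this assay compound 2 gives 81300 nM; the two values lie within the scatter of each other. Compound 3 `Nc1nc(Cl)c2ncn(Cc3ccccc3CCl)c2n1` differs from compound 1 by amino in place of hydrogen on an aromatic carbon. In this assay compound 3 gives only a limit of the assay, > 100000 nM. The measured step is an at least 1.7-fold higher number from compound 1 to compound 3 (0.25 log units; that floor lies within the scatter), its floor being set by the limit of > 100000 nM in this assay, at which 1 of the 3 values shown sits. Compound 4 `Nc1nc(Cl)c2ncn(Cc3cccc(CCl)c3)c2n1` carries the same change from compound 2, (amino in place of hydrogen on an aromatic carbon), at a place described in identical words. The step expected in this assay is a 2.0-fold higher number from compound 2 to compound 4 (0.29 log units; within the scatter), resting on an at least 1.7-fold higher number from compound 1 to compound 3 (0.25 log units; that floor lies within the scatter). For compound 4 the estimate in this assay is 160000 nM, between 80000 nM and 400000 nM, most probably reported as a limit only.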

Compound 4, concentration lethal to 50% of the cells: > 100000 nM
Compound 4: only a limit was reported; the forecaster's own chance of this, stated with the estimate: 75%; the middle value does not contradict the limit.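

In this assay, amino in place of hydrogen on an aromatic carbon gives an at least 1.2-fold higher number from compound 2 to compound 4 (0.08 log units; that floor lies within the scatter), so on this core the step cannot be told from the scatter at its floor. Set beside the step on the core of compound 1, the change shows no reversal of direction, but nothing can be said about whether it carries over with the same size: the same change on two cores in this assay, an at least 1.7-fold higher number (0.25 log units; that floor lies within the scatter) from compound 1 to compound 3 and an at least 1.2-fold higher number (0.08 log units; that floor lies within the scatter) from compound 2 to compound 4; the limit leaves it open whether they differ

Compound 4 is reported only as a limit, > 100000 nM, so its true position stays unknown, and the read-out leaves little room to follow this change upward: the limit of > 100000 nM in this assay, at which 2 of the 4 values shown sit.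

The compounds shown leave open whether methylamino or methoxy on the same carbon would give a readable number in this assay. They also leave open how an amine in place of the chloro group would read on either core.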